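Adding a Methoxy Group to a Chalcone Series

The compounds below may be only part of what the source reports. "The series", "measured", "known", "first", "only" and "open" are said of these compounds alone.

Compound 1 `COc1ccc(/C=C/C(=O)c2ccccc2-c2ccc(OC)c(OC)c2)cc1` gives 320 nM in a functional assay on CNE-2 cells (Homo sapiens) for antiproliferative activity, read by sulforhodamine B assay, with a stated time of 48 h; a higher number here means a weaker inhibitor, a lower number a stronger inhibitor. Compound 2 `COc1ccc(/C=C/C(=O)c2ccccc2-c2ccc(OC)c(OC)c2)cc1OC`, which carries an extra methoxy group, gives 2500 nM; the change methoxy in place of hydrogen on an aromatic carbon gives a step of a 7.8-fold higher number from compound 1 to compound 2 (0.89 log units; beyond the scatter). Compound 3 `COc1ccc(C(=O)/C=C/c2ccccc2-c2ccc(F)cc2)cc1OC` has a core whose difference from that of compound 1 is not broken down here; in this assay compound 3 gives 7600 nM, the highest number among the three measured compounds. Compound 4 `COc1cc(C(=O)/C=C/c2ccccc2-c2ccc(F)cc2)cc(OC)c1OC` is not yet measured. For the measured compounds named here, it differs from compound 3 by methoxy in place of hydrogen on an aromatic carbon, a change of the same kind as the one from compound 1 to compound 2 but not the same: in compound 4 the entering methoxy is also meta to a methoxy group. Going by the values given here, since the only comparable step is the one from compound 1 to compound 2, the number for compound 4 is expected to rise because a 7.8-fold higher number from compound 1 to compound 2 (0.89 log units; beyond the scatter) points that way, giving an estimated step of a 3.3-fold higher number from compound 3 to compound 4 (0.52 log units; beyond the scatter). Compound 4 is therefore estimated at 25000 nM, with a range from 5000 nM to 80000 nM.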

Compound 4, half-maximal inhibitory concentration: 3800 nM
Estimate against measurement, compound 4: 6.6-fold (0.82 log units) above; measured number below the stated range.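

In this assay, methoxy in place of hydrogen on an aromatic carbon gives a 2.0-fold lower number from compound 3 to compound 4 (0.30 log units; within the scatter), so on this core the change leaves no difference that can be told from the scatter. The change therefore does not carry over as a fixed step from one core to the other, and the two pairs part clearly: the same change on two cores in this assay, a 7.8-fold higher number (0.89 log units; beyond the scatter) from compound 1 to compound 2 and a 2.0-fold lower number (0.30 log units; within the scatter) from compound 3 to compound 4, 16-fold (1.19 log units) apart, beyond the scatter of two such steps

This does not show what sets the two steps apart, since the pairs differ in their cores and also in the surroundings of the entering methoxy, which in compound 4 is ortho to a methoxy group and meta to a large group; two pairs also give no general rule for the series. The compounds shown leave open how an ethoxy group or an amine in the same place would behave on each core. They also leave open whether the two cores would part in the same way in another cell line.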